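This account rests on a few compounds, and the source may have more. Where it says the series, first, only, none or still open, it means among the compounds named here.

Among the measured compounds shown here, in a functional assay on the whole organism with Rattus norvegicus as the target (a higher number here means that more compound is needed for the effect, a lower number that less compound is needed), compound 2 (`CCOC(=O)C(=O)Nc1cccc(NC)c1C#N`) gives 0.1 mg/kg, the lower of the two numbers so far, while compound 1 (`CCOC(=O)C(=O)Nc1cccc(N(C)C)c1C#N`) gives 4.2 mg/kg. Next comes compound 3 (`CNc1cccc(NC(=O)C(=O)O)c1C#N`), with the change (hydrogen in place of ethyl on an oxygen next to a carbonyl group), in other words ethoxycarbonyl to carboxy. For the measured compounds named here, the only measured step, a 42-fold lower number from compound 1 to compound 2 (1.62 log units; beyond the scatter), is large, but it is hydrogen in place of methyl on a nitrogen on an aromatic ring, not a change on this oxygen. Going by the values given here, it therefore gives no direct guide, and no measured pair carries the present change. Among the compounds with values here, it shows only that a single change can shift this assay a long way. A moderate move to a higher number is expected, because compound 2 stands low at 0.1 mg/kg. The estimated step is a 3.0-fold higher number from compound 2 to compound 3 (0.48 log units; beyond the scatter), with wide uncertainty. For compound 3 the estimate is 0.3 mg/kg, with an expected range of 0.03 mg/kg to 3 mg/kg.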

Compound 3, dose for half-maximal effect: 0.07 mg/kg
Compound 3: middle estimate off by 4.3-fold (0.63 log units), on the high side; the measured number falls inside the stated range.
By their numbers in this assay, from the lowest: compounds 3 and 2 (each within the scatter of the next); then compound 1.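

In this assay, replacing ethyl with hydrogen on the oxygen next to a carbonyl group gives a 1.4-fold lower number from compound 2 to compound 3 (0.15 log units; within the scatter), so ethoxycarbonyl and carboxy cannot be told apart here. Among the compounds shown here, this is the first reading at this oxygen, and it shows that the ethyl group can be lost without a change beyond the scatter, whereas the change on the aromatic nitrogen gave a 42-fold lower number from compound 1 to compound 2 (1.62 log units; beyond the scatter). No measurement on hand bears on why compound 2 and compound 3 read alike.

From the compounds shown here alone, it remains open whether a longer chain on this oxygen, such as butyl, or a benzyl group would read alike as well, or whether an amine in place of ethoxy, giving an amide, would shift the number. Going by these compounds, it is also open whether carboxy would read the same alongside the dimethylamino group of compound 1.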